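Pyrazole carboxylic acid series: aryl swap at the pyrazole carbon

The source may hold more compounds than are shown below. What is called first, only, known or untested is meant among the compounds shown, and "the series" means these compounds.

Three compounds share one core and differ only in the aryl group on the pyrazole carbon. Compound 1 `Cc1cc(C)cc(-c2c(C)nn(-c3nc(-c4ccc(Cl)c(Cl)c4)c(SC(C)C)s3)c2C(=O)O)c1` gives 2700 nM in a functional assay on BJAB cells (Homo sapiens) for antiproliferative activity, with a stated time of 4 days; a higher number here means that more compound is needed for the effect, a lower number that less compound is needed. Compound 2 `Cc1cc(C#N)cc(-c2c(C)nn(-c3nc(-c4ccc(Cl)c(Cl)c4)c(SC(C)C)s3)c2C(=O)O)c1` gives 4800 nM, and the step of a 1.8-fold higher number from compound 1 to compound 2 (0.25 log units; within the scatter) stays within the scatter. Compound 3 `CNc1cc(-c2c(C)nn(-c3nc(-c4ccc(Cl)c(Cl)c4)c(SC(C)C)s3)c2C(=O)O)ccn1` gives 18000 nM, the highest number of the three; the steps of a 6.7-fold higher number from compound 1 to compound 3 (0.82 log units; beyond the scatter) and a 3.8-fold higher number from compound 2 to compound 3 (0.57 log units; beyond the scatter) both lie beyond the scatter, so compound 3 is the least potent of the measured set.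

Compound 4 `COc1cc(Cl)cc(-c2c(C)nn(-c3nc(-c4ccc(Cl)c(Cl)c4)c(SC(C)C)s3)c2C(=O)O)c1` has not been measured. Its change from compound 3 is 3-chloro-5-methoxyphenyl in place of 2-(methylamino)pyridin-4-yl on an aromatic carbon. For the measured compounds named here, two measured steps bear on this: replacing the ring of carbon only with the pyridinyl cost potency in both a 6.7-fold higher number from compound 1 to compound 3 (0.82 log units; beyond the scatter) and a 3.8-fold higher number from compound 2 to compound 3 (0.57 log units; beyond the scatter), while the swap between two rings of carbon only in a 1.8-fold higher number from compound 1 to compound 2 (0.25 log units; within the scatter) made little difference. Compound 4 returns to a ring of carbon only with one acceptor and no donor, so a clear decrease in number is expected, roughly reversing those steps; the expected step is a 5.1-fold lower number from compound 3 to compound 4 (0.71 log units; beyond the scatter). Compound 4 is therefore estimated at 3500 nM in this assay, with a likely range from 1500 nM to 9000 nM.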

Compound 4, half-maximal effective concentration: 760 nM
For compound 4 the middle estimate is 4.6-fold (0.66 log units) above the measured one, outside the stated range (below it).
By their numbers in this assay, from the lowest: compound 4; then compounds 1 and 2 (each within the scatter of the next); then compound 3.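

In this assay, for the compounds shown here, the earlier compounds left open whether a ring of carbon only at this aromatic carbon could improve on the 3,5-dimethylphenyl group, because the swap to 3-cyano-5-methylphenyl stayed within the scatter; 3-chloro-5-methoxyphenyl now gives a 3.6-fold lower number from compound 1 to compound 4 (0.55 log units; beyond the scatter) and a 6.3-fold lower number from compound 2 to compound 4 (0.80 log units; beyond the scatter), so the choice of groups on such a ring does matter here. Against the 2-(methylamino)pyridin-4-yl group, the same ring gives a 24-fold lower number from compound 3 to compound 4 (1.37 log units; beyond the scatter), the largest step in the set, which makes compound 4 the most potent of the four, with all its steps beyond the scatter and a wider span at this position than the earlier compounds showed. Nothing available accounts for the gain seen with 3-chloro-5-methoxyphenyl.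

The chlorine and the methoxy group occur together on one ring in the compounds shown, so the share of each in these steps remains open. Also open, going by these compounds, is how a trifluoromethyl or ethoxy group on the same ring would read, and whether the gain would persist with a methyl ester in place of the carboxy group.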